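The source may hold more compounds than are shown below. What is called first, only, known or untested is meant among the compounds shown, and "the series" means these compounds.

Measured so far in an ADME assay on HepG2 cells (Homo sapiens) for cytotoxicity, with a stated time of 72 h; on this read-out higher numbers stand for an effect only at larger amounts of compound and lower numbers for an effect already at smaller amounts:
- compound 1 `Cc1cc(NC(=O)Nc2cccc(C(N)=O)c2)c2ccccc2n1`: > 25000 nM (a limit of the assay, not a number)
- compound 2 `Cc1cc(NC(=O)Nc2cccc(F)c2)c2ccccc2n1`: > 25000 nM (a limit of the assay, not a number)
- compound 3 `Cc1cc(NC(=O)Nc2cccc(C(F)(F)F)c2)c2ccccc2n1`: 21000 nM

In this assay, within the data shown here, compound 3 gives 21000 nM, the only true number in the set. The other two readings sit at the limit of > 25000 nM in this assay, at which 2 of the 3 values shown sit.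

The next compound is compound 4 `Cc1cc(NC(=O)Nc2ccc([N+](=O)[O-])c(C(F)(F)F)c2)c2ccccc2n1`, which has nitro in place of hydrogen on an aromatic carbon, ortho to a trifluoromethyl group and para to a large group: nitro in place of hydrogen on an aromatic carbon.

The nearest measured changes are substitutions on an aromatic carbon. These are an at least 1.1-fold lower number from compound 2 to compound 3 (0.07 log units; that floor lies within the scatter) and an at least 1.1-fold lower number from compound 1 to compound 3 (0.07 log units; that floor lies within the scatter), both floors within the scatter, while a step that the two limits leave unreadable from compound 1 to compound 2 cannot be read. None of them introduces nitro, and none adds a group to compound 3, so the data give no direct size for this change.

The expectation therefore starts from compound 3 at 21000 nM, with only a modest move toward a lower number in this assay and a wide margin around it. The expected step is a 1.8-fold lower number from compound 3 to compound 4 (0.24 log units; within the scatter). A reading at the limit of the assay would not be surprising.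

For compound 4 the estimate is 12000 nM, with an expected range from 4000 nM to 25000 nM.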

Compound 4, half-maximal effective concentration: > 25000 nM
Compound 4: only a limit was reported; the forecaster's own chance of this, stated with the estimate: 25%; middle value at least 2.0-fold (0.31 log units) from the limit.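

Among these compounds, this is the first change that adds a group to the ring carrying trifluoromethyl instead of exchanging one group for another: nitro in place of hydrogen, ortho to a trifluoromethyl group and para to a large group, gives an at least 1.1-fold higher number from compound 3 to compound 4 (0.07 log units; that floor lies within the scatter). Nitro at this position therefore brings no move toward a lower number in this assay, and the added heavy atoms leave the reading at the limit of the assay rather than producing a second true number. With this result, the series rests almost entirely on one limit, and only compound 3 carries a number: the limit of > 25000 nM in this assay, at which 3 of the 4 values shown sit.

From the compounds shown here alone, how far compound 4 lies beyond the limit stays unknown, so the size of this step cannot be read beyond its floor, and the steps between compounds that both sit at the limit cannot be read at all. Also open, going by these compounds, is whether an amine or a carboxylic acid in place of the nitro at this position, or nitro on a ring without trifluoromethyl, would give a true number in this assay.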